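Fluoro to Methoxy on the Outer Ring of Compound 1

A few compounds are considered here, and "the series" means these few. Any claim that something is new, unique, unknown or untested is made for them only; others in the source may bear on it.

Compound 1 `COc1ccc(S(=O)(=O)N2CCc3cccc(-c4ccc(F)cc4)c32)cc1` carries a fluoro group on its outer six-membered ring. In a functional assay on KB cells (Homo sapiens) for inhibition, with a stated time of 72 h (a higher number here means a weaker inhibitor, a lower number a stronger inhibitor), compound 1 gives 86 nM, the lowest of the two numbers measured here. Compound 2 `COc1ccc(S(=O)(=O)N2CCc3cccc(-c4cc(OC)c(OC)c(OC)c4)c32)cc1`, which instead bears three methoxy groups on that ring, gives 3690 nM in this assay, a far higher number and well beyond the usual scatter, so compound 1 is the stronger inhibitor of the pair. Compound 3 `COc1ccc(-c2cccc3c2N(S(=O)(=O)c2ccc(OC)cc2)CC3)cc1` has not yet been measured. It differs from compound 1 in a single place: methoxy in place of fluoro on an aromatic carbon. Going by the values given here, no measured pair shows exactly this change, so its effect must be judged indirectly. Because compound 2 with three methoxy groups gives 3690 nM, one methoxy is expected to weaken inhibition only mildly. The expected step of a 2.3-fold higher number from compound 1 to compound 3 (0.37 log units; beyond the scatter) is therefore small, near the edge of the scatter. For compound 3 the estimate in this assay is 200 nM, ranging from 50 nM to 900 nM.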

Compound 3, half-maximal inhibitory concentration: 337 nM
Compound 3: middle estimate off by 1.7-fold (0.23 log units), on the low side, within the range that was stated.
By their numbers in this assay, from the lowest: compound 1; then compound 3; then compound 2.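

Going by these compounds alone, this is the first direct reading of a single change at this position: in this assay, methoxy in place of fluoro, para to a large group, gives a 3.9-fold higher number from compound 1 to compound 3 (0.59 log units; beyond the scatter) while the rest of the molecule stays the same. The position is therefore sensitive to which small group it carries, since exchanging one group for another moves the number beyond the usual scatter, although the step is only modest. No measurement at hand accounts for this step.

The compounds shown leave open how this position would respond to a different kind of group, such as an amine or a carboxylic acid. They also leave open whether a longer chain, such as ethoxy in place of methoxy, would raise the number further or lower it.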